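The source may report more compounds than this note shows. Statements on the series, on what has been measured and on what is new or still open speak of the compounds shown alone.

Working notes on the series.

Compound 1 `CN(C)Cc1ccc2nc(NC(=O)N/N=C/c3c[nH]c4ccccc34)sc2c1` is the parent with a hydrogen on the aromatic nitrogen of the five-membered ring. In a functional assay on NCI-H460 cells (Homo sapiens) for cytotoxicity, read by MTT assay, with a stated time of 72 h (a lower number here means a stronger inhibitor, a higher number a weaker inhibitor), compound 1 gives 2550 nM.

Compound 2 `CN(C)Cc1ccc2nc(NC(=O)N/N=C/c3cn(Cc4ccccc4)c4ccccc34)sc2c1` differs from compound 1 by benzyl in place of hydrogen on an aromatic nitrogen. In this assay compound 2 gives 400 nM; the step is a 6.4-fold lower number from compound 1 to compound 2 (0.80 log units; beyond the scatter), a clear gain for the benzyl compound.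

Compound 3 `CCN(CC)Cc1ccc2nc(NC(=O)N/N=C/c3c[nH]c4ccccc34)sc2c1` differs from compound 1 by diethylamino in place of dimethylamino on a saturated chain carbon bound to an aromatic carbon. In this assay compound 3 gives 3140 nM; the step is a 1.2-fold higher number from compound 1 to compound 3 (0.09 log units; within the scatter), so the two cores give numbers within the usual scatter of each other and are treated here as equivalent starting points. Compound 3 shows the highest of the three numbers, but its step to compound 1 does not separate the two.

Compound 4 `CCN(CC)Cc1ccc2nc(NC(=O)N/N=C/c3cn(Cc4ccccc4)c4ccccc34)sc2c1` has not yet been measured. It differs from compound 3 by benzyl in place of hydrogen on an aromatic nitrogen. The change is the same as that from compound 1 to compound 2, at the same place, and it occurs twice among the compounds shown. Among the compounds with values here, only the single measured instance of it is available, so the expectation for compound 4 rests on that one pair and on the near-identical numbers of compound 1 and compound 3 in this assay.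

For compound 4 a step of about a 6.3-fold lower number from compound 3 to compound 4 (0.80 log units; beyond the scatter) is expected because a 6.4-fold lower number from compound 1 to compound 2 (0.80 log units; beyond the scatter) was seen on the diethylamino-free core. Compound 4 is therefore estimated at 500 nM in this assay, with a likely span from 250 nM to 1000 nM.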

Compound 4, half-maximal inhibitory concentration: 450 nM
The estimate for compound 4 lay 1.1-fold (0.05 log units) above the measured number, within the range that was stated.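

In this assay, benzyl in place of hydrogen on the aromatic nitrogen gives a 7.0-fold lower number from compound 3 to compound 4 (0.84 log units; beyond the scatter), and this gain carries over between the diethylamino and dimethylamino compounds with no separable difference in size: the same change on two cores in this assay, a 6.4-fold lower number (0.80 log units; beyond the scatter) from compound 1 to compound 2 and a 7.0-fold lower number (0.84 log units; beyond the scatter) from compound 3 to compound 4, 1.1-fold (0.04 log units) apart, within the scatter of two such steps

The exchange of amino groups is also unchanged when benzyl is present, at a 1.1-fold higher number from compound 2 to compound 4 (0.05 log units; within the scatter), and it stays within the scatter on both cores: the same change on two cores in this assay, a 1.2-fold higher number (0.09 log units; within the scatter) from compound 1 to compound 3 and a 1.1-fold higher number (0.05 log units; within the scatter) from compound 2 to compound 4, 1.1-fold (0.04 log units) apart, within the scatter of two such steps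

This shows that the two changes behave independently across these four compounds, so the benzyl step read on one core predicted the other here, but it rests on a single pair of amino groups, one nitrogen substituent and one cell line, and it shows neither why the number falls nor that the same transfer holds for any other core.

The compounds shown leave open whether the gain is specific to benzyl or would also appear with a methyl group, a longer chain such as phenethyl, or a benzyl carrying a fluorine or methoxy group on its ring. They also leave open whether a cyclic amine such as piperidine or morpholine, in place of diethylamino, would keep the amine's near-neutral effect on the number and the same additive behaviour.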